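A trifluorophenyl group replaces a trimethylcyclohexyl group

This account rests on a few compounds, and the source may have more. Where it says the series, first, only, none or still open, it means among the compounds named here.

Measured in an ADME assay on MDBK cells (Bos taurus) for cytotoxicity, read by MTT assay; on this read-out lower numbers stand for higher toxicity in this test and higher numbers for lower toxicity in this test:
Compound 1 `OC[C@@H]1[C@@H](O)[C@H](O)[C@@H](O)CN1CCCCCCOc1cc(Cl)ccc1Cl`: 320000 nM
Compound 2 `CC1CC(OCCCCCCN2C[C@H](O)[C@@H](O)[C@H](O)[C@H]2CO)CC(C)(C)C1`: 250000 nM

Within the data shown here, compound 2 stands within the scatter of compound 1, the only other compound measured. Compound 3 `OC[C@@H]1[C@@H](O)[C@H](O)[C@@H](O)CN1CCCCCCOc1c(F)cc(F)cc1F` keeps the shared core and differs from compound 2 as follows: 2,4,6-trifluorophenyl in place of 3,3,5-trimethylcyclohexyl on an oxygen on a saturated carbon. Among the measured compounds shown here, one measured step bears on this change, made at the same place, where 3,3,5-trimethylcyclohexyl took the place of 2,5-dichlorophenyl: a 1.3-fold lower number from compound 1 to compound 2 (0.11 log units; within the scatter). That step stays within the scatter. The new group is a halogen-bearing phenyl, like that of compound 1 at 320000 nM. For the measured compounds named here, no measured compound yet carries 2,4,6-trifluorophenyl itself, so the evidence is thin. No change beyond the scatter is expected, and the expected step is a 1.2-fold higher number from compound 2 to compound 3 (0.08 log units; within the scatter). In this assay compound 3 is estimated at 300000 nM, with an expected range of 140000 nM to 620000 nM.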

Compound 3, half-maximal cytotoxic concentration: > 500000 nM
Compound 3 was reported as a limit; the forecaster's own chance of this, stated with the estimate: 20%; at least 1.6-fold (0.22 log units) between middle value and limit.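

Compound 3 is reported only as a limit, and it is the one compound shown that reaches it: the limit of > 500000 nM in this assay, at which 1 of the 3 values shown sits. In this assay, placing 2,4,6-trifluorophenyl on this oxygen gives an at least 2.0-fold higher number from compound 2 to compound 3 (0.30 log units; that floor lies within the scatter) and an at least 1.5-fold higher number from compound 1 to compound 3 (0.19 log units; that floor lies within the scatter). Both steps are floors that lie within the scatter, so the change shows no clear separation from either earlier compound, though neither 3,3,5-trimethylcyclohexyl nor 2,5-dichlorophenyl gave a limit at this position.

Going by these compounds, the true number for compound 3 stays unknown, and with it the real size of both steps. Also open, on these data alone, is whether a plain phenyl, a phenyl bearing an amine or a carboxylic acid, or a longer chain to the oxygen would keep the reading at this limit.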